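Thiophene for Oxazole in an Inactive Cytotoxicity Series

A few compounds are considered here, and "the series" means these few. Any claim that something is new, unique, unknown or untested is made for them only; others in the source may bear on it.

Measured compounds:
Compound 1 `Cc1noc(C)c1C(c1ccccc1)N1CCN(c2ncnc3c2cnn3-c2ccccc2)CC1`: > 25000 nM
Compound 2 `N#Cc1cccc(C(c2ccccc2)N2CCN(c3ncnc4c3cnn4-c3ccccc3)CC2)c1`: > 25000 nM
Compound 3 `c1ccc(C(c2cccnc2)N2CCN(c3ncnc4c3cnn4-c3ccccc3)CC2)cc1`: > 25000 nM

All three were tested in a functional assay on cells (Rhabdomyosarcoma cell, Homo sapiens) for cytotoxicity; a higher number here means a weaker inhibitor, a lower number a stronger inhibitor. In this assay compound 1 gives only a limit, > 25000 nM, not a number. Compound 2 likewise gives only a limit, > 25000 nM. Compound 3 too gives only a limit, > 25000 nM. Where compound 1 stands is therefore known only as a limit, and the steps a step that the two limits leave unreadable from compound 1 to compound 2 and a step that the two limits leave unreadable from compound 1 to compound 3 cannot be read in size or direction, as summed up by the limit of > 25000 nM in this assay, at which 3 of the 3 values shown sit.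

The new compound is compound 4, `Cc1ccsc1C(c1ccccc1)N1CCN(c2ncnc3c2cnn3-c2ccccc2)CC1`, not yet measured. It differs from compound 1 as follows:
3-methylthiophen-2-yl in place of 3,5-dimethyl-1,2-oxazol-4-yl on a saturated chain carbon bound to an amine nitrogen in a ring and an aromatic carbon

The steps a step that the two limits leave unreadable from compound 1 to compound 2 and a step that the two limits leave unreadable from compound 1 to compound 3 exchange the same group at the same place, yet neither gives a readable size, so no step beyond the scatter can be expected in either direction. Compound 4 is therefore expected to remain at the limit, with an estimate of 40000 nM in a range of 20000 nM to 100000 nM. For compound 4 this means an expected step that the limit leaves unreadable from compound 1 to compound 4.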

Compound 4, half-maximal inhibitory concentration: > 25000 nM
Compound 4 was reported as a limit; the forecaster's own chance of this, stated with the estimate: 85%; the middle value lies beyond the limit too.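

Compound 4 gives only a limit, as do compound 1, compound 2 and compound 3, so no step among them can be read in size or direction: the limit of > 25000 nM in this assay, at which 4 of the 4 values shown sit.

The compounds shown leave open whether any group at this place would give an actual number in this assay.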